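Carbamoyl in Place of Methoxycarbonyl on a Glycine Transporter Ligand

A few compounds are considered here, and "the series" means these few. Any claim that something is new, unique, unknown or untested is made for them only; others in the source may bear on it.

Measured so far:
compound 1 `CCc1nnc(-c2ccc(-c3ccccc3)cc2)n1-c1cccc(CN(C)C)c1C` gives 29000 nM
compound 2 `CCc1nnc(-c2ccc(-c3ccccc3)cc2)n1-c1cccc(C(=O)OC)c1C` gives 5100 nM

Among the compounds with values here, in an assay on C6 glioma cells for displacement of a labelled ligand from sodium- and chloride-dependent glycine transporter 1 (Rattus norvegicus), read by scintillation counting, with stated times of 30 min and 10 min (a higher number here means a weaker inhibitor, a lower number a stronger inhibitor), compound 2 stands at the lowest of the two numbers, and compound 1 is its only neighbour, separated by the step of a 5.7-fold lower number from compound 1 to compound 2 (0.75 log units; beyond the scatter). Compound 3 `CCc1nnc(-c2ccc(-c3ccccc3)cc2)n1-c1cccc(C(N)=O)c1C` differs from compound 2 by amino in place of methoxy on a carbonyl carbon. That measured step concerns a different group and so offers no direct guide to this change; nothing measured swaps methoxy for amino on a carbonyl carbon. No step beyond the scatter is expected, so the estimated step is a 1.2-fold higher number from compound 2 to compound 3 (0.07 log units; within the scatter). Compound 3 is therefore estimated at 6000 nM, in a range from 1500 nM to 25000 nM.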

Compound 3, half-maximal inhibitory concentration: 3900 nM
Estimate against measurement, compound 3: 1.5-fold (0.19 log units) above, within the range that was stated.
By their numbers in this assay, from the lowest: compounds 3 and 2 (each within the scatter of the next); then compound 1.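

In this assay the swap of methoxy for amino on a carbonyl carbon gives a 1.3-fold lower number from compound 2 to compound 3 (0.12 log units; within the scatter) and so no change beyond the scatter, even though amino brings a hydrogen-bond donor that methoxy lacks. Carbamoyl too stands clear of (dimethylamino)methyl, with a 7.4-fold lower number from compound 1 to compound 3 (0.87 log units; beyond the scatter) here, so both carbonyl groups shown share the same side of that comparison. Nothing measured here bears on the reason for these results. 

Open still is whether a carboxylic acid in this place, or an ethoxy or dimethylamino group on the same carbonyl carbon, would stay at this level.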